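Ester Chain Swap in a Glycoside Series

This account rests on a few compounds, and the source may have more. Where it says the series, first, only, none or still open, it means among the compounds named here.

Compound 1, `C=C(C)CCOC(=O)C[C@@H]1C(C(=O)OC)=CO[C@@H](O[C@@H]2O[C@H](CO)[C@@H](O)[C@H](O)[C@H]2O)/C1=C/C`, gives in a functional assay on SK-BR-3 cells (Homo sapiens) for antiproliferative activity, read by MTT assay, with a stated time of 72 h (a lower number here means a stronger inhibitor, a higher number a weaker inhibitor), only a limit, > 15000 nM.
Compound 2, `C/C=C1/[C@H](O[C@@H]2O[C@H](COC(C)=O)[C@@H](OC(C)=O)[C@H](OC(C)=O)[C@H]2OC(C)=O)OC=C(C(=O)OC)[C@H]1CC(=O)OCCC1CCCCC1`, gives in this assay likewise only a limit, > 15000 nM.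

Neither measured compound yields a number in this assay. Compound 2 therefore stands at the limit of > 15000 nM in this assay, at which 2 of the 2 values shown sit, and nothing in these two results separates it from compound 1; both simply failed to reach a measurable inhibition within the tested range.

Compound 3, `C/C=C1/[C@H](O[C@@H]2O[C@H](COC(C)=O)[C@@H](OC(C)=O)[C@H](OC(C)=O)[C@H]2OC(C)=O)OC=C(C(=O)OC)[C@H]1CC(=O)OCCCC`, is not yet measured. It differs from compound 2 in one place: ethyl in place of cyclohexyl on a saturated chain carbon, two bonds along the chain from an oxygen next to a carbonyl group. The rest of the shared core, the sugar with its four acetyl groups and the methyl ester, stays unchanged.

For the measured compounds named here, no step between measured compounds is available to say how this kind of change moves the read-out. With compound 2 already at a limit, no shift beyond the usual scatter is expected from compound 2 to compound 3; the estimated step is a step that the limit leaves unreadable from compound 2 to compound 3. Compound 3 is expected to give about 30000 nM in this assay, with a likely range from 10000 nM to 100000 nM, and most probably again only a limit.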

Compound 3, half-maximal inhibitory concentration: > 15000 nM
Compound 3 gave a limit, no number; the forecaster's own chance of this, stated with the estimate: 80%; the middle value lies beyond the limit too.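

In this assay compound 2 and compound 3 both give only a limit, so the size of the step between them cannot be read: the limit of > 15000 nM in this assay, at which 3 of the 3 values shown sit.

The compounds shown leave open how strongly any of them acts on these cells, and whether having cyclohexyl or ethyl at this place on the chain changes the read-out at all.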